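A few compounds are considered here, and "the series" means these few. Any claim that something is new, unique, unknown or untested is made for them only; others in the source may bear on it.

Measured so far:
- compound 1, `C[C@]1(CN2CCc3nc(-c4ccc(F)c(F)c4)oc3C2)Cn2cc([N+](=O)[O-])nc2O1`: > 32 ug/mL in an ADME assay on Vero cells (Chlorocebus sabaeus) for cytotoxicity, read by MTT assay, with a stated time of 72 h; a lower number here means that less compound is tolerated, a higher number that more compound is tolerated
- compound 2, `C[C@]1(CN2CCc3nc(N4CCC(F)(F)CC4)ccc3C2)Cn2cc([N+](=O)[O-])nc2O1`: "not determined" (no result reported)

Compound 1 sits at the limit of > 32 ug/mL in this assay, at which 1 of the 2 values shown sits; this value is a limit of this assay and not a number. For compound 2 this assay records "not determined" (no result reported), so no result is reported and compound 2 stands nowhere on the numbers shown. Within the data shown here, the only value shown in this assay is the limit of compound 1.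

Compound 3, `C[C@]1(CN2CCc3nc(-c4cccc(F)c4F)ccc3C2)Cn2cc([N+](=O)[O-])nc2O1`, is not yet measured. It differs from compound 2 in one place: 2,3-difluorophenyl in place of 4,4-difluoropiperidin-1-yl on an aromatic carbon. Among the measured compounds shown here, no step between measured compounds exists here, so the size of the change cannot be read from the series. Given that the only recorded value in this assay is the limit for compound 1, no direction beyond the scatter is expected for compound 3; a further limit is the most likely outcome.

For compound 3 the estimate in this assay is 32 ug/mL, expected to fall between 12 ug/mL and 64 ug/mL.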

Compound 3, half-maximal cytotoxic concentration: > 32 ug/mL
Compound 3: a limit, no number; the forecaster's own chance of this, stated with the estimate: 70%; the middle value lies on the limit itself.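

No new step can be read in this assay, as compound 2 has no reported result there. Compound 3 gives > 32 ug/mL, which is a limit and not a number. The compounds shown leave open whether 2,3-difluorophenyl and 4,4-difluoropiperidin-1-yl at this place differ at all in this assay.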